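From 4-chlorophenyl to 2,5-dihydroxyphenyl in the series

A few compounds are considered here, and "the series" means these few. Any claim that something is new, unique, unknown or untested is made for them only; others in the source may bear on it.

In a functional assay on cells (Erythrocyte, Rattus norvegicus) for inhibition, read by hemolysis, with a stated time of 1 h (on this read-out higher numbers stand for weaker inhibition and lower numbers for stronger inhibition), compound 1 `COc1cc(OC)c(OC)cc1/C=C/C(=O)c1ccc(Cl)cc1` gives 2.3 ug/mL. Compound 2 `COc1cc(OC)c(OC)cc1/C=C/C(=O)c1ccc(Cl)c([N+](=O)[O-])c1` gives 2.15 ug/mL and compound 3 `COc1cc(C(=O)/C=C/c2cc(OC)c(OC)cc2OC)ccc1O` gives 2.16 ug/mL, so all three values lie within the scatter of one another.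

Compound 4 `COc1cc(OC)c(OC)cc1/C=C/C(=O)c1cc(O)ccc1O` is still unmeasured. Its change from the core of compound 1 is 2,5-dihydroxyphenyl in place of 4-chlorophenyl on a carbonyl carbon. Among the compounds with values here, the only measured step, nitro in place of hydrogen on an aromatic carbon, is a 1.1-fold lower number from compound 1 to compound 2 (0.03 log units; within the scatter), within the scatter, and it does not exchange the whole group. Within the data shown here, no measured step covers this replacement, so the range stays wide.

The expected step is a 1.0-fold lower number from compound 1 to compound 4 (0.02 log units; within the scatter), none beyond the scatter. The estimate for compound 4 is 2.2 ug/mL, with an expected range of 1.2 ug/mL to 4 ug/mL.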

Compound 4, half-maximal inhibitory concentration: 2.1 ug/mL
Beside the measured number, compound 4's estimate is 1.0-fold (0.02 log units) above it; the measured number falls inside the stated range.
By their numbers in this assay, from the lowest: compounds 4, 2, 3 and 1 (each within the scatter of the next).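

Replacing the whole aryl group on the carbonyl carbon, rather than adding a substituent to it, also stays within the scatter in this assay (a 1.1-fold lower number from compound 1 to compound 4 (0.04 log units; within the scatter)). At this position, 4-chlorophenyl and 2,5-dihydroxyphenyl cannot be told apart on this read-out, although only the latter carries hydrogen-bond donors and acceptors. No supporting measurement bears on why the values stay so close.

Still open, going by these compounds, is whether an amine or a carboxylic acid on this aromatic ring would give a step beyond the scatter. The same question stands for a longer chain in place of the ring.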